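Ester change in a nitro dihydropyridine pair: cyclohexyl to ethyl

The source may report more compounds than this note shows. Statements on the series, on what has been measured and on what is new or still open speak of the compounds shown alone.

Measured compounds in a functional assay (cardiac atrium) for agonist activity, with Cavia porcellus as the target; a lower number here means that less compound is needed, a higher number that more compound is needed for the effect:
compound 1, `CC1=NC(C)=C([N+](=O)[O-])C(c2cccnc2)/C1=C(\O)OC1CCCCC1`, 2760 nM
compound 2, `CC1=NC(C)=C([N+](=O)[O-])C(c2ccncc2)/C1=C(\O)OC1CCCCC1`, 4940 nM

Compound 1 and compound 2 share the core and differ only in pyridin-4-yl in place of pyridin-3-yl on a saturated ring carbon; the step of a 1.8-fold higher number from compound 1 to compound 2 (0.25 log units; within the scatter) lies within the scatter, so the two measured compounds are not separated in this assay, and compound 1 stands at one end of a pair that is effectively a single level.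

Compound 3, `CCO/C(O)=C1\C(C)=NC(C)=C([N+](=O)[O-])C1c1cccnc1`, keeps the pyridin-3-yl of compound 1 and changes the ester: ethyl in place of cyclohexyl on an oxygen on an unsaturated carbon. Going by the values given here, no measured step touches the ester side; the only step seen concerns the pyridyl attachment and is within the scatter, so it gives no guidance on size or direction here. The change removes a ring and shortens the chain. For compound 3 an expected step of a 2.9-fold higher number from compound 1 to compound 3 (0.46 log units; beyond the scatter) is taken, toward a higher number, with a wide range because nothing measured constrains it. Compound 3 is thus estimated at 8000 nM, range 2000 nM to 30000 nM.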

Compound 3, half-maximal effective concentration: 8840 nM
Estimate against measurement, compound 3: 1.1-fold (0.04 log units) below; the measured number falls inside the stated range.
By their numbers in this assay, from the lowest: compounds 1, 2 and 3 (each within the scatter of the next, the first and the last beyond it).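

Ethyl in place of cyclohexyl on the oxygen gives the first step in this series that separates two compounds in this assay: a 3.2-fold higher number from compound 1 to compound 3 (0.51 log units; beyond the scatter). The pyridyl change, a 1.8-fold higher number from compound 1 to compound 2 (0.25 log units; within the scatter), did not separate its pair, so this oxygen substituent is the only place shown where a single change moves the number beyond the scatter, though only modestly, and in this one pair the cyclohexyl compound has the lower number. Nothing measured here accounts for the step.

With only cyclohexyl and ethyl shown at this position, it remains open where a butyl chain, a benzyl or a cyclopentyl would fall relative to these two. Also open, on these data alone, is whether the same exchange on the pyridin-4-yl of compound 2 would give a similar step.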